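Ortho-chloro on the sulfonyl ring of compound 3

This account rests on a few compounds, and the source may have more. Where it says the series, first, only, none or still open, it means among the compounds named here.

Compound 1 `COc1ccc(CN(c2cc(OC)c(OC)c(OC)c2)S(=O)(=O)c2ccccc2)cc1` gives > 50000 nM in a functional assay on MCF7 cells (Homo sapiens) for inhibition, read by MTT assay, with a stated time of 48 h (on this read-out lower numbers stand for stronger inhibition and higher numbers for weaker inhibition), a limit of the assay rather than a number. Compound 2 `COc1cc(N(Cc2csc3ccc(Cl)cc23)S(=O)(=O)c2ccc(C)cc2)cc(OC)c1OC` gives 8950 nM in this assay. Compound 3 `COc1cc(N(Cc2nc3ccccc3[nH]2)S(=O)(=O)c2ccccc2)cc(OC)c1OC` gives 27300 nM in this assay.

Among the numbers shown, compound 3 stands highest; the nearest number, that of compound 2, is lower by a step beyond the scatter, while compound 1 contributes only a limit (the limit of > 50000 nM in this assay, at which 1 of the 3 values shown sits). Within the data shown here, the one measured step, an at least 1.8-fold lower number from compound 1 to compound 3 (0.26 log units; that floor lies within the scatter), concerns the group on the saturated chain carbon and not the sulfonyl ring, so it does not bear on what follows. Compound 4 `COc1cc(N(Cc2nc3ccccc3[nH]2)S(=O)(=O)c2ccccc2Cl)cc(OC)c1OC` differs from compound 3 in one place: chloro in place of hydrogen on an aromatic carbon. Among the measured compounds shown here, no measured pair isolates this change; compound 2 carries a different group on its sulfonyl ring but also a different chain group, so its value cannot be read as a step. With nothing to lean on, compound 4 is expected to stay close to compound 3, a step of a 1.1-fold lower number from compound 3 to compound 4 (0.04 log units; within the scatter) that lies within the scatter. Compound 4 is therefore estimated at 25000 nM, between 8000 nM and 60000 nM.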

Compound 4, half-maximal inhibitory concentration: 38100 nM
The estimate for compound 4 lay 1.5-fold (0.18 log units) below the measured number; measured number inside the range.
By their numbers in this assay, from the lowest: compound 2; then compounds 3 and 4 (each within the scatter of the next). At a limit, above all of these: compound 1.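

Chloro in place of hydrogen on an aromatic carbon, ortho to a large group, gives a 1.4-fold higher number from compound 3 to compound 4 (0.14 log units; within the scatter) in this assay. Among these compounds, this is the first measured step on the sulfonyl ring, as the earlier step concerned only the group on the chain carbon, and it shows that phenylsulfonyl and (2-chlorophenyl)sulfonyl cannot be told apart on this read-out in the presence of the 1H-benzimidazol-2-yl group. Compound 1 sits at a limit of the assay and not at a number, and the scale of this read-out ends there: the limit of > 50000 nM in this assay, at which 1 of the 4 values shown sits.

Going by these compounds, whether an amine or a carboxylic acid at this same place would shift the number beyond the scatter stays open. Also open, on these data alone, is whether chloro would give a similar step with another chain group, since compound 2 differs from compound 4 in more than one place.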